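This account rests on a few compounds, and the source may have more. Where it says the series, first, only, none or still open, it means among the compounds named here.

Measured so far in a functional assay on SGC-7901 cells (Homo sapiens) for antiproliferative activity, read by MTT assay, with a stated time of 24 h; on this read-out higher numbers stand for weaker inhibition and lower numbers for stronger inhibition:
Compound 1 `CCCCOc1ccc(C(=O)NNC(=O)c2ccc(NS(=O)(=O)c3cnc(O)nc3O)cc2)cc1` gives 14700 nM.
Compound 2 `Cc1ccccc1C(=O)NNC(=O)c1ccc(NS(=O)(=O)c2cnc(O)nc2O)cc1` gives > 20000 nM, which is a limit of the assay and not a number.
Compound 3 `CCCCOc1ccc(C(=O)NNC(=O)c2cccc(NS(=O)(=O)c3cnc(O)nc3O)c2)cc1` gives 7370 nM.

Compound 4 `Cc1ccccc1C(=O)NNC(=O)c1cccc(NS(=O)(=O)c2cnc(O)nc2O)c1` has not yet been measured in this assay. It comes from compound 3 by one change: 2-methylphenyl in place of 4-butoxyphenyl on a carbonyl carbon. The same change has been made once before, from compound 1 to compound 2 (2-methylphenyl in place of 4-butoxyphenyl on a carbonyl carbon); there it gave an at least 1.3-fold higher number from compound 1 to compound 2 (0.13 log units; that floor lies within the scatter). That step is only a floor, because compound 2 sits at the limit of > 20000 nM in this assay, at which 1 of the 3 values shown sits. Compounds 1 and 3 share the same atoms joined differently; how their two cores differ is not broken down here. The place of the change is described in the same words for both pairs, so this is the same change. Between compound 3 and compound 1 the numbers lie within the usual scatter.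

For compound 4 the step from compound 3 is expected to be a 3.0-fold higher number from compound 3 to compound 4 (0.47 log units; beyond the scatter), at least as large as the earlier one, since the earlier one rests on compound 2 reaching the limit of > 20000 nM in this assay, at which 1 of the 3 values shown sits, and its true size may be larger. The number expected for compound 4 in this assay is 22000 nM, estimated between 9000 nM and 60000 nM, with a fair chance that only a limit is reported.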

Compound 4, half-maximal inhibitory concentration: > 20000 nM
Compound 4 was reported as a limit (the forecaster's own chance of this, stated with the estimate: 55%); the middle value does not contradict the limit.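

In this assay, setting 2-methylphenyl in place of 4-butoxyphenyl on a carbonyl carbon gives an at least 2.7-fold higher number from compound 3 to compound 4 (0.43 log units; beyond the scatter). This step is only a floor, since the result for compound 4 is a limit of the assay and not a number, and the result for compound 2 is one too: the limit of > 20000 nM in this assay, at which 2 of the 4 values shown sit. On the core of compound 3 the floor lies beyond the scatter and on the core of compound 1 it does not, so the change weakens inhibition clearly on one core, but the two floors cannot show whether it carries over with the same size: the same change on two cores in this assay, an at least 1.3-fold higher number (0.13 log units; that floor lies within the scatter) from compound 1 to compound 2 and an at least 2.7-fold higher number (0.43 log units; beyond the scatter) from compound 3 to compound 4; the limit leaves it open whether they differ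

The compounds shown hold only these two groups at this place, and the swap removes the butoxy chain and brings in the methyl group in a single step, so the share of each stays open. A plain phenyl, a longer chain or an amine on the same carbonyl carbon could show whether any other group keeps or improves the inhibition.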